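Cyano on the Phenyl of Compound 2: an Expected Outcome

The source may report more compounds than this note shows. Statements on the series, on what has been measured and on what is new or still open speak of the compounds shown alone.

Of the compounds shown here, two have been measured so far. Compound 1 `C=Cc1cncc(O[C@@H]2CCNC2)c1` carries a vinyl group on its core, while compound 2 `c1ccc(-c2cncc(O[C@@H]3CCNC3)c2)cc1` carries a phenyl group in the same position. In an assay on a protein complex for binding affinity to Neuronal acetylcholine receptor; alpha4/beta2 (Rattus norvegicus) (a higher number here means a weaker inhibitor, a lower number a stronger inhibitor), compound 1 gives 883 nM. In this assay compound 2 gives 1820 nM. For the measured compounds named here, the only step available is a 2.1-fold higher number from compound 1 to compound 2 (0.31 log units; beyond the scatter), so compound 2 stands as the higher of the two numbers and the weaker binder by a margin beyond the scatter.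

Compound 3 `N#Cc1ccc(-c2cncc(O[C@@H]3CCNC3)c2)cc1` differs from compound 2 by cyano in place of hydrogen on an aromatic carbon. Going by the values given here, no measured step bears directly on this change; the one step that exists concerns the exchange of the vinyl group for the phenyl, not a substituent on the phenyl itself. With nothing to point in either direction, the author expects a step that stays within the usual scatter, a 1.4-fold lower number from compound 2 to compound 3 (0.15 log units; within the scatter), with the number kept close to that of compound 2. Compound 3 is therefore estimated at 1300 nM in this assay, with a range from 350 nM to 5000 nM.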

Compound 3, half-maximal inhibitory concentration: 544 nM
For compound 3 the middle estimate is 2.4-fold (0.38 log units) above the measured one; measured number inside the range.
By their numbers in this assay, from the lowest: compounds 3 and 1 (each within the scatter of the next); then compound 2.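

The phenyl ring of compound 2 turns out to respond to substitution: in this assay, cyano in place of hydrogen on an aromatic carbon, para to a large group, gives a 3.3-fold lower number from compound 2 to compound 3 (0.52 log units; beyond the scatter), a modest step but one that clearly exceeds the noise of the measurement. For the compounds shown here, the earlier step, a 2.1-fold higher number from compound 1 to compound 2 (0.31 log units; beyond the scatter), concerned only the exchange of the group on the shared core, so this is the first sign that a substituent on the phenyl itself can move the number, and here it moves it toward a stronger inhibitor. Nothing available explains why the cyano group has this effect on the number.

With one substituent at one place, the compounds shown cannot tell whether this step is particular to cyano or would also appear with another group there, such as a methoxy, an amine or a carboxylic acid. They also leave open whether cyano would give a similar number on another carbon of the phenyl ring, and whether the step would hold for any other receptor.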